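Trifluoromethyl on the benzyl ether of compound 3

The source may hold more compounds than are shown below. What is called first, only, known or untested is meant among the compounds shown, and "the series" means these compounds.

Measured so far in a functional assay on KBVIN cells (Homo sapiens) for antiproliferative activity, read by sulforhodamine B assay, with a stated time of 72 h; on this read-out higher numbers stand for weaker inhibition of growth and lower numbers for stronger inhibition of growth:
compound 1 `Cc1cc(=O)oc2cc(SCc3cccnc3)ccc12` gives > 35200 nM.
compound 2 `COc1cc(CSc2ccc3c(C)cc(=O)oc3c2)cc(OC)c1` gives > 29200 nM.
compound 3 `CCc1cc(=O)c2ccc(OCc3ccccc3)c(C)c2o1` gives 24800 nM.

The value of compound 1 is a limit of this assay and not a number, see (the limit of > 35200 nM in this assay, at which 1 of the 3 values shown sits). The value of compound 2 is likewise a limit and not a number, see (the limit of > 29200 nM in this assay, at which 1 of the 3 values shown sits). For the measured compounds named here, compound 3 is therefore the only member of the set with a number in this assay; the two others sit at limits, so no ordering among the three can be drawn from them.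

Compound 4 `CCc1cc(=O)c2ccc(OCc3cccc(C(F)(F)F)c3)c(C)c2o1` has not yet been measured. It differs from compound 3 by trifluoromethyl in place of hydrogen on an aromatic carbon. Going by the values given here, no step between two measured compounds in this set touches the benzyl ether, so the size of the step from compound 3 to compound 4 cannot be read off any measured pair.

The expectation is a step within or close to the scatter, a 1.4-fold lower number from compound 3 to compound 4 (0.14 log units; within the scatter), with no firm direction. Compound 4 is estimated at 18000 nM in this assay. The range for compound 4 is estimated from 5000 nM to 45000 nM.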

Compound 4, concentration for 50% growth inhibition: > 27600 nM
Compound 4 was reported as a limit; the forecaster's own chance of this, stated with the estimate: 25%; middle value at least 1.5-fold (0.18 log units) from the limit.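

Notes on the benzyl ether: in this assay compound 4 gives > 27600 nM, which is a limit of the assay and not a number: the limit of > 27600 nM in this assay, at which 1 of the 4 values shown sits.

For the compounds shown here, this is the first reading at this position, and it gives an at least 1.1-fold higher number from compound 3 to compound 4 (0.04 log units; that floor lies within the scatter) as a floor only, with no upper end. Trifluoromethyl in place of hydrogen on an aromatic carbon, meta to a large group, therefore yields no lower number in this series, which the earlier compounds could not show, as no measured pair touched the benzyl ether.

From the compounds shown here alone, how far compound 4 really lies from compound 3 stays open, and so does whether there is any true difference between them, as the floor of the step does not clear the scatter. Also open, going by these compounds, is whether an amine or a carboxylic acid at this place on the benzyl ring would lower the number, and the steps that involve the limits of compound 1 and compound 2 cannot be read.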